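The source may hold more compounds than are shown below. What is called first, only, known or untested is meant among the compounds shown, and "the series" means these compounds.

Among the measured compounds shown here, in a functional assay on HeLa cells (Homo sapiens) for antiproliferative activity, read by MTT assay, with a stated time of 72 h (on this read-out lower numbers stand for stronger inhibition and higher numbers for weaker inhibition), compound 3 `COc1ccc(N2C(=O)COc3ccc(-c4cccc(NS(=O)(=O)c5ccc(F)cc5)c4)cc32)cc1` gives 13200 nM, the only true number among the compounds measured so far. Compound 1 `COc1cccc(N2C(=O)COc3ccc(-c4cccc(NS(=O)(=O)c5ccc(F)cc5)c4)cc32)c1` reads > 40000 nM, which is a limit of the assay and not a number. Compound 2 `O=C1COc2ccc(-c3cccc(NS(=O)(=O)c4ccc(F)cc4)c3)cc2N1C1CC1` reads > 40000 nM, which is also a limit.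

Compound 4 `O=C1COc2ccc(-c3cccc(NS(=O)(=O)c4ccc(F)cc4)c3)cc2N1C1CCCCC1` has cyclohexyl in place of 4-methoxyphenyl on an amide-type nitrogen in a ring. The closest guide is compound 2, whose cyclopropyl is also a non-aromatic ring of carbon only. Putting 4-methoxyphenyl in its place gave an at least 3.0-fold lower number from compound 2 to compound 3 (0.48 log units; beyond the scatter). Compound 1 points the same way, with an at least 3.0-fold lower number from compound 1 to compound 3 (0.48 log units; beyond the scatter). The remaining comparison, a step that the two limits leave unreadable from compound 1 to compound 2, cannot be read.

Losing the 4-methoxyphenyl is therefore expected to raise the number in this assay by a modest amount or more, and the result may be reported only as a limit. The expected change is a 2.7-fold higher number from compound 3 to compound 4 (0.42 log units; beyond the scatter). For compound 4 the estimated value is 35000 nM, within an expected range of 14000 nM to 80000 nM.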

Compound 4, half-maximal inhibitory concentration: 10800 nM
Compound 4: middle estimate off by 3.2-fold (0.51 log units), on the high side, and the stated range ends above it.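

In this assay, an aromatic ring on the amide-type nitrogen is not required: cyclohexyl and 4-methoxyphenyl cannot be told apart, with a 1.2-fold lower number from compound 3 to compound 4 (0.09 log units; within the scatter). Whether the group is aromatic does not decide the outcome on its own, since cyclohexyl in place of cyclopropyl gives an at least 3.7-fold lower number from compound 2 to compound 4 (0.56 log units; beyond the scatter), and cyclohexyl in place of 3-methoxyphenyl gives an at least 3.7-fold lower number from compound 1 to compound 4 (0.56 log units; beyond the scatter), so one non-aromatic and one aromatic group both fall behind cyclohexyl. The true sizes of these last two steps remain unknown because compound 1 and compound 2 rest on an assay limit: the limit of > 40000 nM in this assay, at which 2 of the 4 values shown sit.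

On these data alone, it remains open whether an open chain such as n-butyl, or a cyclohexyl carrying an amine or a hydroxyl, would match compound 4 at this nitrogen. The compounds shown also leave open whether any group here could bring the number well below those of compound 3 and compound 4.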